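The source may hold more compounds than are shown below. What is called first, only, known or untested is meant among the compounds shown, and "the series" means these compounds.

Compound 1 `Oc1ccccc1-c1cc(-c2cccs2)cc(-c2ccccc2O)n1` gives in a functional assay on HeLa cells (Homo sapiens) for cytotoxicity, read by CCK-8 assay (a lower number here means a stronger inhibitor, a higher number a weaker inhibitor), a reading of > 50000 nM, which is a limit of the assay and not a number.
Compound 2 `Oc1ccccc1-c1cc(-c2ccsc2)cc(-c2ccccc2O)n1` gives in this assay a reading of > 50000 nM, again a limit.
Compound 3 `Oc1ccccc1-c1cc(-c2ccco2)cc(-c2ccccc2O)n1` gives in this assay a reading of > 50000 nM, also a limit.

Compound 3 therefore stands nowhere on a scale of numbers: its reading is a limit, and the two other readings are limits as well, so all three sit at the limit of > 50000 nM in this assay, at which 3 of the 3 values shown sit. The steps among them, a step that the two limits leave unreadable from compound 1 to compound 2, a step that the two limits leave unreadable from compound 1 to compound 3 and a step that the two limits leave unreadable from compound 2 to compound 3, cannot be read in size or direction, because both ends of each step are limits.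

Compound 4 `Oc1ccccc1-c1cc(-c2ccoc2)cc(-c2ccccc2O)n1` has not been measured. It differs from compound 3 by furan-3-yl in place of furan-2-yl on an aromatic carbon. The measured steps that bear on this change, the exchanges of one five-membered ring for another on the same aromatic carbon, all stayed at the limit, so they give no measurable size to build on. The expectation is that the step from compound 3 to compound 4 in this assay is a number no higher from compound 3 to compound 4 (the limit leaves the size open), most likely another limit. Compound 4 is estimated at 50000 nM, with a range from 15000 nM to 200000 nM.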

Compound 4, half-maximal inhibitory concentration: > 50000 nM
Compound 4: a limit, no number; the forecaster's own chance of this, stated with the estimate: 85%; the middle value sits exactly at the limit.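

For the compounds shown here, compound 4 also gives a limit and not a number, so no step from compound 1, compound 2 or compound 3 to compound 4 can be read in size or direction: the limit of > 50000 nM in this assay, at which 4 of the 4 values shown sit. The compounds shown leave open what actual number any of the four would give in this assay.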